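The compounds below may be only part of what the source reports. "The series", "measured", "known", "first", "only" and "open" are said of these compounds alone.

Compounds measured so far:
- compound 1, `COc1ccccc1N1C(=O)CSC1c1cc(F)cc(C(=O)O)c1`, giving 0%
- compound 2, `COc1ccc(C)cc1N1C(=O)CSC1c1cccc(C(=O)NCCCCc2ccccc2)c1`, giving 92%
- compound 3, `COc1ccccc1N1C(=O)CSC1C(=O)NCCCCc1ccccc1`, giving 60%

In a functional assay on MG-63 cells (Homo sapiens) for inhibition, read by CCK-8 assay, with a stated time of 72 h, tested at 1 uM (on this read-out higher numbers stand for more inhibition at the one concentration tested (going by the name of the read-out) and lower numbers for less inhibition), compound 2 stands highest of the three numbers with 92%. The nearest is compound 3 at 60%, a reading that lies lower by more than the usual scatter of repeated measurements. The furthest is compound 1 at 0%, lower still and again well beyond the scatter. For the measured compounds named here, compound 1 and compound 3 each differ from compound 2 in more than one place, so no single step between measured compounds is available to lean on.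

Compound 4, `COc1cc(F)ccc1N1C(=O)CSC1c1cccc(C(=O)NCCCCc2ccccc2)c1`, has not yet been measured in this assay. It differs from compound 2 in one place: 4-fluoro-2-methoxyphenyl in place of 2-methoxy-5-methylphenyl on an amide-type nitrogen in a ring. The group that leaves and the group that enters are of the same size and carry the same count of donors and acceptors, so the shared core and the long amide side chain of compound 2 are kept unchanged.

Going by the values given here, with no comparable step among the measured compounds, a small step downward, or none beyond the scatter, is what is expected from this change; the estimated step is a number 10 percentage points lower from compound 2 to compound 4 (within the scatter). Compound 4 is therefore estimated at 82%, with a likely range from 58% to 96%.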

Compound 4, a percentage reported as inhibition, at one concentration (the size of the read-out at that concentration, not a potency): 92%
Compound 4: the middle estimate sits 10 percentage points below what was measured; the measured number falls inside the stated range.
By their numbers in this assay, from the lowest: compound 1; then compound 3; then compounds 2 and 4 (each within the scatter of the next).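

In this assay, putting 4-fluoro-2-methoxyphenyl in place of 2-methoxy-5-methylphenyl on the amide-type nitrogen in the ring gives no change at the digits printed from compound 2 to compound 4 (within the scatter), with the shared core and the long amide side chain unchanged. For the compounds shown here, this is the first comparison here that differs in one place only, so it is the first direct reading of this position: this one exchange of substituted phenyl groups leaves the inhibition at the single tested concentration where it was. The reading gives the size of the effect at that concentration and is not a potency, so the two compounds could still differ at lower concentrations, and no measurement of any property of these two groups bears on the result.

The pair also cannot show whether the methyl and the fluorine each matter, because both change in the same step, and a lone 2-methoxyphenyl carrying the same amide side chain would separate them. Going by these compounds, it also remains open whether the number in this assay would be higher, lower or level with a very different group on the phenyl ring, such as a dimethylamino group or a morpholine.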